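Swapping a para methylsulfanyl for fluoro on a dihydropyrimidine

A few compounds are considered here, and "the series" means these few. Any claim that something is new, unique, unknown or untested is made for them only; others in the source may bear on it.

Of the compounds shown here, three have been measured in a functional assay on 786-0 cells (Homo sapiens) for inhibition, read by sulforhodamine B assay, with a stated time of 48 h (a lower number here means a stronger inhibitor of growth, a higher number a weaker inhibitor of growth), so far. Compound 1, with structure `CCOC(=O)C1=C(C)NC(=S)NC1c1ccc(O)c(O)c1`, gives 28.3 ug/mL in this assay. Compound 2, with structure `CCOC(=O)C1=C(C)NC(=S)NC1c1ccc(SC)cc1`, gives 5.3 ug/mL in this assay. Compound 3, with structure `CCCc1ccc(C2NC(=O)NC(C)=C2C(=O)OCC)cc1`, gives 18.8 ug/mL in this assay. Among these three numbers, compound 2 stands lowest, so of the three it is the strongest inhibitor of growth; the gap to compound 3 and the larger gap to compound 1 both lie beyond the usual scatter of repeated measurements.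

The next compound, compound 4, has structure `CCOC(=O)C1=C(C)NC(=S)NC1c1ccc(F)cc1` and has not yet been measured in this assay. It differs from compound 2 in one place: fluoro in place of methylsulfanyl on an aromatic carbon. Among the compounds with values here, no pair of measured compounds differs by exactly this change, so there is no directly comparable step to lean on. The other two measured compounds, which carry different groups on the same ring or a changed core, both give higher numbers than compound 2, which suggests that compound 2 sits at a favourable point and that a change there is more likely to raise the number than lower it. Compound 4 is therefore expected to be a somewhat weaker inhibitor of growth, with an estimated step of a 2.3-fold higher number from compound 2 to compound 4 (0.35 log units; beyond the scatter) in this assay. The estimate for compound 4 is 12 ug/mL, with a plausible range from 5 ug/mL to 30 ug/mL.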

Compound 4, concentration for 50% growth inhibition: 24.5 ug/mL
Estimate against measurement, compound 4: 2.0-fold (0.31 log units) below; measured number inside the range.
By their numbers in this assay, from the lowest: compound 2; then compounds 3, 4 and 1 (each within the scatter of the next).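

In this assay, within the data shown here, the swap gives a 4.6-fold higher number from compound 2 to compound 4 (0.66 log units; beyond the scatter) and so provides the first comparison in this set in which only one group changes. It shows that the group on this aromatic carbon, para to a large group, matters on this core: the step lies beyond the usual scatter of repeat measurements. Methylsulfanyl, with its carbon and sulfur, gives the lower number here, and fluoro, a single heavy atom, gives the higher one. Nothing measured here accounts for this difference.

As far as these compounds go, with only these two groups compared directly at this position, it remains open whether the sulfur atom matters or whether other groups would match methylsulfanyl, and methoxy, chloro or ethylsulfanyl in the same place would help to separate those possibilities. It is also open whether the same swap would give a similar step on the core of compound 3, since neither fluoro nor methylsulfanyl appears on that core among the compounds shown.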